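Replacing the 2-(hydroxymethyl)pyrrolidin-1-yl group of compound 2

The compounds below may be only part of what the source reports. "The series", "measured", "known", "first", "only" and "open" are said of these compounds alone.

Values measured in a functional assay on HL-60 cells (Homo sapiens) for inhibition, read by MTT assay, with a stated time of 48 h, tested at 10 uM (a higher number here means more inhibition of growth at the concentration tested, a lower number less inhibition of growth), are these
- compound 1 `Cc1cc(=O)c2c(O)c(CN3CCCC3)c(O)c([C@H]3CCN(C)C[C@H]3O)c2o1` gives 38%
- compound 2 `Cc1cc(=O)c2c(O)c(CN3CCCC3CO)c(O)c([C@H]3CCN(C)C[C@H]3O)c2o1` gives 33%

Within the data shown here, compound 2 lies within the usual scatter of compound 1, the only other measured compound, so these two values set no order between them.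

Compound 3 `Cc1cc(=O)c2c(O)c(CN(C)CC(=O)O)c(O)c([C@H]3CCN(C)C[C@H]3O)c2o1` differs from compound 2 in one place, on a saturated chain carbon bound to an aromatic carbon. There, (carboxymethyl)(methyl)amino stands in place of 2-(hydroxymethyl)pyrrolidin-1-yl (carboxymethyl)(methyl)amino in place of 2-(hydroxymethyl)pyrrolidin-1-yl on a saturated chain carbon bound to an aromatic carbon and the entering group has no ring.

Among the measured compounds shown here, the only measured step that bears on this is a number 5 percentage points lower from compound 1 to compound 2 (within the scatter) and it put hydroxymethyl in place of hydrogen on a saturated ring carbon of that same group. That step was small, but the new change replaces the whole group, so one step is a weak guide to the direction in this assay for this swap. The estimate is a number 5 percentage points lower from compound 2 to compound 3 (within the scatter) and no step beyond the scatter is firmly expected, though the margins stay wide. Compound 3 is expected to give 28% within a range of 10% to 46% at this stage.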

Compound 3, percent growth inhibition at one concentration: 23%
Compound 3: middle estimate off by 5 percentage points, on the high side, and the stated range covers the measured number.
By their numbers in this assay, from the lowest: compounds 3, 2 and 1 (each within the scatter of the next, the first and the last beyond it).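

In this assay, the earlier step changed only a small part of the group on a saturated chain carbon bound to an aromatic carbon, whereas this result replaces the whole group. Putting (carboxymethyl)(methyl)amino in place of 2-(hydroxymethyl)pyrrolidin-1-yl gives a number 10 percentage points lower from compound 2 to compound 3 (within the scatter), so this swap does not separate the two groups, even though the entering group has no ring. Set against the plain pyrrolidin-1-yl group, the same entering group gives a number 15 percentage points lower from compound 1 to compound 3 (beyond the scatter), the first step at this position to clear the usual scatter, though only modestly, and no measurement available here explains it.

The compounds shown leave open whether that modest drop goes with the carboxylic acid or with the missing ring: 2-carboxypyrrolidin-1-yl would keep the ring and carry the acid, while dimethylamino would have neither. Also open, going by these compounds, is how a longer chain such as (2-carboxyethyl)(methyl)amino, or the methyl ester of the acid, would read in this assay.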